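The compounds below may be only part of what the source reports. "The series", "measured", "known", "first", "only" and "open" are said of these compounds alone.

Measured in an in vitro functional assay on cells for agonist activity at Bombesin receptor subtype-3 (Homo sapiens), read by luminescence and calcium flux; a higher number here means that more compound is needed for the effect, a lower number that less compound is needed:
compound 1 `O=C(O)c1ccccc1-c1ccc(CCc2ncc(CCC3CCCCC3)[nH]2)cc1`: 642 nM
compound 2 `O=C(O)c1ccccc1-c1ccc(CCc2ncc(CC3CCOCC3)[nH]2)cc1`: 338 nM
compound 3 `CCCCc1cnc(C(CC)Cc2ccc(-c3ccccc3C(=O)O)cc2)[nH]1`: 2720 nM

Compound 2 gives the lowest number of the three in this assay. Against its nearest neighbour the step is a 1.9-fold lower number from compound 1 to compound 2 (0.28 log units; within the scatter), within the scatter; the furthest value, that of compound 3, lies beyond the scatter from that of compound 2. Compound 4 `O=C(O)c1ccccc1-c1ccc(CCc2ncc(-c3ccccc3)[nH]2)cc1` is not yet measured. Relative to compound 2 it carries phenyl in place of (oxan-4-yl)methyl on an aromatic carbon. Among the measured compounds shown here, the one measured step at that place, a 1.9-fold lower number from compound 1 to compound 2 (0.28 log units; within the scatter), moved the number little; compound 3 differs from compound 2 in more than one place and gives no clean step. For the measured compounds named here, a phenyl at that place has no precedent, so the expectation is uncertain. For compound 4 in this assay the expected step is a 1.8-fold higher number from compound 2 to compound 4 (0.25 log units; within the scatter), with an estimate of 600 nM and a range of 200 nM to 2000 nM.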

Compound 4, half-maximal effective concentration: 4950 nM
Compound 4: the middle estimate sits 8.3-fold (0.92 log units) below what was measured; measured number outside the range, above it.
By their numbers in this assay, from the lowest: compounds 2 and 1 (each within the scatter of the next); then compounds 3 and 4 (each within the scatter of the next).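

Phenyl on this aromatic carbon behaves differently from either saturated group in this assay: it gives a clear rise against (oxan-4-yl)methyl (a 15-fold higher number from compound 2 to compound 4 (1.17 log units; beyond the scatter)) and a smaller one against 2-cyclohexylethyl (a 7.7-fold higher number from compound 1 to compound 4 (0.89 log units; beyond the scatter)). Among the compounds shown here, the step between those two saturated groups stayed within the scatter, so only this change shows that the position responds to the group placed there. No evidence on hand accounts for the rise. Still open, from the compounds shown here alone, is whether benzyl or 2-phenylethyl, which keep a saturated chain before the aromatic ring, would bring the number back towards that of compound 2.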